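The source may report more compounds than this note shows. Statements on the series, on what has been measured and on what is new or still open speak of the compounds shown alone.

Values in a functional assay on WI-38 cells (Homo sapiens) for cytotoxicity; on this read-out lower numbers stand for stronger inhibition and higher numbers for weaker inhibition:
- compound 1 `O=C1c2ccccc2C(=O)N1c1ccccc1`: > 100 ug/mL
- compound 2 `O=C1c2ccccc2C(=O)N1c1ccccc1-c1ccccc1`: > 100 ug/mL

Compound 2 gives > 100 ug/mL, which is a limit and not a number. Compound 1 gives > 100 ug/mL, also a limit. Going by the values given here, the series so far therefore offers only (the limit of > 100 ug/mL in this assay, at which 2 of the 2 values shown sit), and no measured number exists to anchor the next step.

Compound 3 `O=C1c2ccccc2C(=O)N1c1ccccc1[N+](=O)[O-]` carries nitro in place of phenyl on an aromatic carbon, ortho to a large group: nitro in place of phenyl on an aromatic carbon.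

Among the compounds with values here, the sole measured step that bears on this change is a step that the two limits leave unreadable from compound 1 to compound 2. It concerns the same aromatic carbon, but it gives no size and no direction. With nothing readable to carry over, no step beyond the scatter is expected in this assay, and no direction can be argued. The estimated step is a number no higher from compound 2 to compound 3 (the limit leaves the size open). A report of compound 3 as another limit is the most likely outcome, though a number close to that limit would not surprise. For compound 3 the expected value is 100 ug/mL, with an estimated range from 40 ug/mL to 150 ug/mL.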

Compound 3, half-maximal inhibitory concentration: > 100 ug/mL
Compound 3 was reported as a limit; the forecaster's own chance of this, stated with the estimate: 70%; the middle value sits exactly at the limit.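

In this assay compound 3 gives > 100 ug/mL, a limit and not a number. No step among compound 1, compound 2 and compound 3 can therefore be read, as all three sit at the same limit: the limit of > 100 ug/mL in this assay, at which 3 of the 3 values shown sit.

The compounds shown leave open whether hydrogen, phenyl and nitro on this aromatic carbon differ at all on this read-out.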